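A few compounds are considered here, and "the series" means these few. Any claim that something is new, unique, unknown or untested is made for them only; others in the source may bear on it.

Working notes on the series. Compound 3 `NC(=O)c1c(NC(=O)c2ccccc2Cl)sc2c1CCN(Cc1cc(Cl)cc(Cl)c1)C2` in a functional assay on HeLa cells (Homo sapiens) for antiproliferative activity, with a stated time of 24 h (a higher number here means a weaker inhibitor, a lower number a stronger inhibitor), gives 19600 nM; this is the lowest of the two numbers measured, but compound 1 `NC(=O)c1c(NC(=O)c2ccccc2Cl)sc2c1CCN(Cc1ccccc1Cl)C2` with 27500 nM sits within the scatter of it, so no order between the two is claimed. Compound 2 `NC(=O)c1c(NC(=O)c2ccccc2Cl)sc2c1CCN(Cc1ccc(Cl)cc1)C2` gives only a limit of the assay, > 50000 nM, as noted in the limit of > 50000 nM in this assay, at which 1 of the 3 values shown sits. The measured steps are an at least 1.8-fold higher number from compound 1 to compound 2 (0.25 log units; that floor lies within the scatter), a 1.4-fold lower number from compound 1 to compound 3 (0.15 log units; within the scatter) and an at least 2.5-fold lower number from compound 2 to compound 3 (0.40 log units; beyond the scatter); all three move chlorine around the benzyl ring on the ring amine nitrogen.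

Within the data shown here, compound 4 `NC(=O)c1c(NC(=O)c2ccccc2Cl)sc2c1CCN(C(=S)Nc1ccccc1Br)C2` differs from compound 3 by a group of 10 heavy atoms (7 carbon, 1 nitrogen, 1 sulfur, 1 bromine; one six-membered aromatic ring of carbon only) in place of a group of 9 heavy atoms (7 carbon, 2 chlorine; one six-membered aromatic ring of carbon only), on an amine nitrogen in a ring; the entering group carries a double bond outside aromatic rings and one hydrogen-bond donor and one acceptor, which no measured compound has. Among the measured compounds shown here, none of the measured steps bears on this exchange, and the whole series spans a narrow band around the weak end. The expected step is therefore a 1.3-fold higher number from compound 3 to compound 4 (0.11 log units; within the scatter), with no direction beyond the scatter. Compound 4 is estimated at 25000 nM, with a range from 7000 nM to 90000 nM.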

Compound 4, half-maximal inhibitory concentration: 24600 nM
Compound 4: the middle estimate sits 1.0-fold (0.01 log units) above what was measured, within the range that was stated.
By their numbers in this assay, from the lowest: compounds 3, 4 and 1 (each within the scatter of the next). At a limit, above all of these: compound 2.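

The ring amine nitrogen also tolerates a group that is not a benzyl: the entering group, with its double bond outside aromatic rings and its hydrogen-bond donor and acceptor, stays level with the chlorobenzyl compounds in this assay, with a 1.3-fold higher number from compound 3 to compound 4 (0.10 log units; within the scatter) and a 1.1-fold lower number from compound 1 to compound 4 (0.05 log units; within the scatter). The exchange therefore gives no step beyond the scatter, and the added donor and acceptor have no readable consequence here. Compound 2 stands at a limit of the assay, so the only reading is an at least 2.0-fold lower number from compound 2 to compound 4 (0.30 log units; that floor lies within the scatter), which does not separate the two beyond the scatter: the limit of > 50000 nM in this assay, at which 1 of the 4 values shown sits.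

Open is whether any group at this position leaves the weak band, since every group shown carries an aromatic ring of carbon only; a carboxylic acid or a short chain ending in an amine would test that. Also open, going by these compounds, is what the sulfur and the bromine each contribute, which a carbonyl in place of the sulfur or a chlorine in place of the bromine would address.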